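Chalcone Aryl Swap on a Shared Pyridine-Ether Core

The compounds below may be only part of what the source reports. "The series", "measured", "known", "first", "only" and "open" are said of these compounds alone.

Compound 1, `CNC(=O)c1cc(Oc2ccc(C(=O)/C=C/c3ccco3)cc2)ccn1`, carries a furan-2-yl group on its enone chain. In a functional assay on PC-3 cells (Homo sapiens) for cytotoxicity, read by MTT assay, with a stated time of 72 h (on this read-out higher numbers stand for weaker inhibition and lower numbers for stronger inhibition), compound 1 gives "not determined" (no result reported): no result was reported for it, so it cannot be placed on this read-out. Its closest measured neighbour, compound 2, `CNC(=O)c1cc(Oc2ccc(C(=O)/C=C/c3ccc(Cl)c(Cl)c3)cc2)ccn1`, which bears a 3,4-dichlorophenyl group in the same position, gives 8260 nM in this assay, a weak figure.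

Compound 3, `CNC(=O)c1cc(Oc2ccc(C(=O)/C=C/c3ccc(OC)cc3)cc2)ccn1`, is to be measured in this assay. It differs from compound 1 by 4-methoxyphenyl in place of furan-2-yl on a double-bonded chain carbon bound to a double-bonded chain carbon. Among the compounds with values here, no measured step covers this exchange. Since compound 1 has no value and compound 2 shows only a weak result, the change is expected to shift potency little, likely no further than the scatter, with any movement leaning toward weaker inhibition. On that basis compound 3 is estimated at 10000 nM in this assay, expected to fall between 3000 nM and 35000 nM.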

Compound 3, half-maximal inhibitory concentration: > 50000 nM
Compound 3 gave a limit, no number; the forecaster's own chance of this, stated with the estimate: 20%; middle value at least 5.0-fold (0.69 log units) away from the limit.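

In this assay compound 3 yields only a limit of the assay, > 50000 nM, and not a number. On the double-bonded chain carbon bound to a double-bonded chain carbon, 4-methoxyphenyl in place of 3,4-dichlorophenyl gives an at least 6.0-fold higher number from compound 2 to compound 3 (0.78 log units; beyond the scatter), which shows that the read-out at this position depends on the aryl group it carries, something a single measured compound could not show. The full size of this step stays unknown because the reading for compound 3 has no upper end: the limit of > 50000 nM in this assay, at which 1 of the 3 values shown sits.

The exchange between compound 1 and compound 3 cannot be read, so furan-2-yl remains unplaced relative to either aryl group. The compounds shown also leave open whether a 4-chlorophenyl group, with a single chlorine, would read closer to compound 2 or to compound 3.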